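The source may hold more compounds than are shown below. What is called first, only, known or untested is meant among the compounds shown, and "the series" means these compounds.

In a functional assay on V79 cells (Cricetulus griseus) for cytotoxicity, read by colony formation (a lower number here means a stronger inhibitor, a higher number a weaker inhibitor), compound 1 (`CCNCC1CCN(c2c(F)cc3c(=O)c(C(=O)O)cn(C4CC4)c3c2Cl)C1`) gives 11 ug/mL; 11 ug/mL; < 11 ug/mL (3 entries) as its entries. One of these entries for compound 1 is a limit and not a number. For the measured compounds named here, compound 2 (`CCNCC1CCN(c2c(F)cc3c(=O)c(C(=O)O)cn(C4CC4)c3c2C(F)(F)F)C1`) gives 120 ug/mL as its only number, and one further entry for it holds no single number. That reading is higher than the numbers for compound 1, and a higher number here means a weaker inhibitor. Compound 3 (`NC1CCN(c2c(F)cc3c(=O)c(C(=O)O)cn(C4CC4)c3c2C(F)(F)F)CC1`) carries 4-aminopiperidin-1-yl in place of 3-((ethylamino)methyl)pyrrolidin-1-yl on an aromatic carbon, ortho to a fluoro group and ortho to a trifluoromethyl group (4-aminopiperidin-1-yl in place of 3-((ethylamino)methyl)pyrrolidin-1-yl on an aromatic carbon), and the rest of compound 2 stays the same. Going by the values given here, no measured pair shows what this exchange does in this assay, so no shift beyond the usual scatter is expected, and neither direction is favoured. The expected step of a 1.3-fold lower number from compound 2 to compound 3 (0.12 log units; within the scatter) is therefore small. Compound 3 is estimated at 90 ug/mL, with an expected range from 20 ug/mL to 300 ug/mL in this measurement.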

Compound 3, half-maximal inhibitory concentration: 20 ug/mL
Beside the measured number, compound 3's estimate is 4.5-fold (0.65 log units) above it; measured number inside the range.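

In this assay, the group on this aromatic carbon proves able to shift the reading on its own: 4-aminopiperidin-1-yl in place of 3-((ethylamino)methyl)pyrrolidin-1-yl gives a 6.0-fold lower number from compound 2 to compound 3 (0.78 log units; beyond the scatter). This is the only measured pair shown that differs in one place, with the trifluoromethyl group and the rest of the core unchanged, so the shift belongs to this exchange alone. Nothing measured here gives a reason for the shift.

As far as these compounds go, whether the exchange acts the same way when a chloro group stands in place of trifluoromethyl, as in compound 1, remains open. Also open, from the compounds shown here alone, is which part of the exchange counts, the ring or its side chain, a question that a 3-aminopyrrolidin-1-yl group on the same carbon could help to separate.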